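A Fourth Variation on the Shared Core

The compounds below may be only part of what the source reports. "The series", "measured", "known", "first", "only" and "open" are said of these compounds alone.

Compound 1 `CC(C)(C)c1ccc(-n2nc(-c3ccc(C(F)(F)F)cc3O)nc2-c2ccccc2O)cc1` carries a tert-butyl group on one of its aromatic rings. Within the data shown here, in a functional assay on PC-12 cells (Rattus norvegicus) for cytotoxicity, read by MTT assay, with stated times of 2 h and 24 h, tested at 10 uM (a higher number here means a stronger effect of the compound at the concentration tested, a lower number a weaker effect), compound 1 gives 81.1%, the lowest of the three numbers measured so far. Compound 2 `Oc1cc(C(F)(F)F)ccc1-c1nc(-c2ccccc2O)n(-c2ccc(Cl)cc2)n1` gives 96.1%, and compound 3 `COc1ccc(-n2nc(-c3ccc(C(F)(F)F)cc3O)nc2-c2ccccc2O)cc1` gives 98.9%. The step of a number 15 percentage points higher from compound 1 to compound 2 (beyond the scatter) and the step of a number 17.8 percentage points higher from compound 1 to compound 3 (beyond the scatter) both replace the tert-butyl and both lift the read-out beyond the usual scatter. Between compound 2 and compound 3 the step of a number 2.8 percentage points higher from compound 2 to compound 3 (within the scatter) is too small to tell the two apart.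

Compound 4 `Oc1cc(C(F)(F)F)ccc1-c1nc(-c2ccccc2O)n(-c2ccc(OC(F)(F)F)cc2)n1` has not yet been measured. It differs from compound 1 in one place: trifluoromethoxy in place of tert-butyl on an aromatic carbon. The two measured steps away from compound 1, a number 15 percentage points higher from compound 1 to compound 2 (beyond the scatter) and a number 17.8 percentage points higher from compound 1 to compound 3 (beyond the scatter), are the ones that bear on this change, since each also swaps out the tert-butyl, and a rise of comparable size is therefore expected in this assay. For compound 4 the expected value is 94%, within a range from 82% to 100%, which amounts to an expected step of a number 12.9 percentage points higher from compound 1 to compound 4 (beyond the scatter).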

Compound 4, a percentage reported as activity, at one concentration (the size of the read-out at that concentration, not a potency): 92.5%
Compound 4: middle estimate off by 1.5 percentage points, on the high side, and the stated range covers the measured number.
By their numbers in this assay, from the lowest: compound 1; then compounds 4, 2 and 3 (each within the scatter of the next).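

In this assay, a third replacement of the tert-butyl again moves the read-out beyond the scatter (a number 11.4 percentage points higher from compound 1 to compound 4 (beyond the scatter)), so the rise now holds for chloro, methoxy and trifluoromethoxy alike, with no compound shown going against it. Trifluoromethoxy cannot be told apart from the other two replacements, since both remaining steps stay within the scatter (a number 6.4 percentage points lower from compound 3 to compound 4 (within the scatter); a number 3.6 percentage points lower from compound 2 to compound 4 (within the scatter)), even though the first of them only swaps a methyl on an oxygen for a trifluoromethyl. Nothing measured here explains why these three groups read alike or why tert-butyl stands apart.

On these data alone, whether an amine or a carboxylic acid at this place would read like these three or like tert-butyl remains open. So does whether a longer chain such as n-hexyl would follow tert-butyl, the only compound here with a clearly different reading.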